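Propargyl on the indole nitrogen of two carbamate regioisomers

A few compounds are considered here, and "the series" means these few. Any claim that something is new, unique, unknown or untested is made for them only; others in the source may bear on it.

Measured so far:
compound 1, `CCN(CC)C(=O)Oc1ccc2[nH]ccc2c1`: > 100000 nM
compound 2, `CCN(CC)C(=O)Oc1ccc2cc[nH]c2c1`: > 100000 nM
compound 3, `C#CCn1ccc2cc(OC(=O)N(CC)CC)ccc21`: 16500 nM

Compound 1, `CCN(CC)C(=O)Oc1ccc2[nH]ccc2c1`, is taken in an assay on isolated protein for inhibition of Amine oxidase [flavin-containing] B (Homo sapiens), read by fluorescence, with stated times of 10 min, 10 s and 20 min; on this read-out lower numbers stand for stronger inhibition and higher numbers for weaker inhibition; it gives only a limit, > 100000 nM. Compound 2, `CCN(CC)C(=O)Oc1ccc2cc[nH]c2c1`, likewise gives only a limit in this assay, > 100000 nM. The difference between the two cores is not broken down here. Compound 3, `C#CCn1ccc2cc(OC(=O)N(CC)CC)ccc21`, gives 16500 nM in this assay.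

Compound 3 arises from compound 1 by one change, (propargyl in place of hydrogen on an aromatic nitrogen). The step is an at least 6.0-fold lower number from compound 1 to compound 3 (0.78 log units; beyond the scatter); it can be stated only as a lower bound because of the limit of > 100000 nM in this assay, at which 2 of the 3 values shown sit.

Compound 4, `C#CCn1ccc2ccc(OC(=O)N(CC)CC)cc21`, is not yet measured in this assay. It arises from compound 2 by propargyl in place of hydrogen on an aromatic nitrogen, the same change, at the same kind of place, as that from compound 1 to compound 3. The step is expected to be about an at least 5.0-fold lower number from compound 2 to compound 4 (0.69 log units; beyond the scatter), resting on the step from compound 1 to compound 3 of an at least 6.0-fold lower number from compound 1 to compound 3 (0.78 log units; beyond the scatter) and on compound 2 sitting at the limit > 100000 nM. Compound 4 is therefore estimated to give 20000 nM in this assay. Four of five such measurements for compound 4 are expected between 5000 nM and 80000 nM.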

Compound 4, half-maximal inhibitory concentration: 1840 nM
Compound 4: middle estimate off by 11-fold (1.04 log units), on the high side; the measured number lies below the stated range.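

In this assay, propargyl in place of hydrogen on an aromatic nitrogen gives an at least 54-fold lower number from compound 2 to compound 4 (1.73 log units; beyond the scatter), so the direction seen on the first carbamate regioisomer carries over to the second. Compound 3 gives 16500 nM and compound 4 gives 1840 nM, but the two steps can be said to agree only in direction and cannot be ranked in size: the same change on two cores in this assay, an at least 6.0-fold lower number (0.78 log units; beyond the scatter) from compound 1 to compound 3 and an at least 54-fold lower number (1.73 log units; beyond the scatter) from compound 2 to compound 4; the limit leaves it open whether they differ. From the compounds shown here alone, compound 2 gives only a limit, > 100000 nM, so the step from it is a lower bound and its true size stays unknown: the limit of > 100000 nM in this assay, at which 2 of the 4 values shown sit.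

The compounds shown do not tell how a methyl, an allyl or a longer alkyne chain on the same nitrogen would compare with propargyl. They also leave open what the diethyl carbamate contributes, since a dimethyl carbamate, or an amide or ether in its place, lies outside this set, and whether the change would carry over to a third core.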